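This account rests on a few compounds, and the source may have more. Where it says the series, first, only, none or still open, it means among the compounds named here.

Compound 1 `Cc1ccc(-c2ccc(C)n2-c2ccc(-c3nc4ccccc4s3)cc2)cc1`: 17800 nM
Compound 2 `Cc1ccc(-c2ccc(F)cc2)n1-c1ccc(-c2nc3ccccc3s2)cc1`: 11800 nM
Compound 3 `COc1cc2nc(-c3ccc(-n4c(C)ccc4-c4ccc(C)cc4)cc3)sc2c(OC)c1OC`: 12300 nM

These three compounds were tested in a functional assay on MDA-MB-231 cells (Homo sapiens) for cytotoxicity, read by MTT assay, with a stated time of 72 h; a higher number here means a weaker inhibitor, a lower number a stronger inhibitor. Compound 1 and compound 2 differ in a single place, (fluoro in place of methyl on an aromatic carbon), and this change gave the step of a 1.5-fold lower number from compound 1 to compound 2 (0.18 log units; within the scatter). Compound 3 gives a number within the scatter of both compound 1 and compound 2. The difference between the core of compound 1 and the core of compound 3 is not broken down here. Compound 4 `COc1cc2nc(-c3ccc(-n4c(C)ccc4-c4ccc(F)cc4)cc3)sc2c(OC)c1OC` has not yet been measured in this assay. It is related to compound 3 by the same change, (fluoro in place of methyl on an aromatic carbon). Resting on that earlier step, the expected step is a 1.4-fold lower number from compound 3 to compound 4 (0.14 log units; within the scatter). Compound 4 is therefore estimated at 9000 nM, with a likely range from 4000 nM to 20000 nM.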

Compound 4, half-maximal inhibitory concentration: 13100 nM
Beside the measured number, compound 4's estimate is 1.5-fold (0.16 log units) below it; the range from low to high includes it.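

In this assay the swap from 4-methylphenyl to 4-fluorophenyl gives a 1.1-fold higher number from compound 3 to compound 4 (0.03 log units; within the scatter) and so leaves the number unmoved on this core. Set beside the earlier step on the core of compound 1, the two steps agree: the same change on two cores in this assay, a 1.5-fold lower number (0.18 log units; within the scatter) from compound 1 to compound 2 and a 1.1-fold higher number (0.03 log units; within the scatter) from compound 3 to compound 4, 1.6-fold (0.21 log units) apart, within the scatter of two such steps. This shows that the change behaves alike on these two cores, but neither step stands beyond the scatter, so it does not show that the change has any real effect on either core, or that a larger effect would carry over.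

The compounds shown leave open whether another group at this place, such as an amine, a carboxylic acid or a longer chain, would shift the number beyond the scatter. They also leave open how the change behaves on any further core.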